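This account rests on a few compounds, and the source may have more. Where it says the series, first, only, none or still open, it means among the compounds named here.

Compound 1 `CCCn1c(=O)[nH]c2nc(-c3ccc(S(=O)(=O)N4CCN(c5ccc(Br)cc5)CC4)cc3)[nH]c2c1=O` carries a 4-bromophenyl on the piperazine nitrogen of the shared core. In an assay on CHO cells for displacement of a labelled ligand from adenosine receptor A2b (Homo sapiens), read by scintillation counting, with a stated time of 75 min, in the presence of a further agent that is not named here (on this read-out lower numbers stand for stronger inhibition and higher numbers for weaker inhibition), compound 1 gives 0.0835 nM, the lowest of the three numbers measured. Compound 2 `CCCn1c(=O)[nH]c2nc(-c3ccc(S(=O)(=O)N4CCN(c5ccccc5)CC4)cc3)[nH]c2c1=O` gives 0.643 nM, and compound 3 `CCCn1c(=O)[nH]c2nc(-c3ccc(S(=O)(=O)N4CCN(c5cccc(Cl)c5)CC4)cc3)[nH]c2c1=O` gives 0.342 nM. The two steps away from compound 1 are both modest and beyond the scatter: a 7.7-fold higher number from compound 1 to compound 2 (0.89 log units; beyond the scatter) and a 4.1-fold higher number from compound 1 to compound 3 (0.61 log units; beyond the scatter). Between the other two, a 1.9-fold lower number from compound 2 to compound 3 (0.27 log units; within the scatter), which lies within the scatter.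

Compound 4 `CCCn1c(=O)[nH]c2nc(-c3ccc(S(=O)(=O)N4CCN(Cc5ccc(Br)c(F)c5)CC4)cc3)[nH]c2c1=O` is not yet measured. It differs from compound 1 in one place: 4-bromo-3-fluorobenzyl in place of 4-bromophenyl on an amine nitrogen in a ring. The measured steps only show how a substituent on the aromatic ring shifts the number; none of them shows what inserting a methylene between the ring nitrogen and the aromatic ring does, and none shows a fluorine. So the measured steps bear on the change only loosely, and they suggest that alterations at this end of the molecule move the number by modest amounts rather than large ones.

Compound 4 is therefore expected to give 0.3 nM, within a range from 0.06 nM to 1.5 nM. This estimate corresponds to an expected step of a 3.6-fold higher number from compound 1 to compound 4 (0.56 log units; beyond the scatter), a weakening that is uncertain in size.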

Compound 4, inhibition constant: 0.473 nM
For compound 4 the middle estimate is 1.6-fold (0.20 log units) below the measured one; the measured number falls inside the stated range.
By their numbers in this assay, from the lowest: compound 1; then compounds 3, 4 and 2 (each within the scatter of the next).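

In this assay the change from 4-bromophenyl to 4-bromo-3-fluorobenzyl on this amine nitrogen in a ring gives a 5.7-fold higher number from compound 1 to compound 4 (0.75 log units; beyond the scatter) and is the first step shown that enlarges the group there, from 7 to 9 heavy atoms, and brings in both a methylene and a fluorine. Even so, compound 4 gives 0.473 nM in this same read-out, so this combined change remains a modest step rather than a large one. The benzyl compound also does not separate from the two compounds that lack bromine, with a 1.4-fold higher number from compound 3 to compound 4 (0.14 log units; within the scatter) and a 1.4-fold lower number from compound 2 to compound 4 (0.13 log units; within the scatter) as its steps, leaving compound 1 alone apart from the other three. No measurement is available that would explain these numbers.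

Going by these compounds, because compound 4 differs in two respects at once, what a 4-bromobenzyl group would give remains open, and the shares of the methylene and the fluorine in the step cannot be told apart. Also open, on these data alone, is what a carboxylic acid or a longer chain would do on this nitrogen in place of a group carrying an aromatic ring.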